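Compound 3 to compound 4: fluoro out, hydrogen in

A few compounds are considered here, and "the series" means these few. Any claim that something is new, unique, unknown or untested is made for them only; others in the source may bear on it.

In a functional assay on HL-60 cells (Homo sapiens) for inhibition, read by MTT assay, with a stated time of 72 h (a higher number here means a weaker inhibitor, a lower number a stronger inhibitor), compound 3 `COc1cc(OC)cc(N2CCN(C(=O)c3oc(C)nc3-c3cccc(F)c3)CC2)c1` gives 28.2 nM. That value lies within the scatter of the two other measured compounds: compound 2 `COc1cc(OC)cc(N2CCN(C(=O)c3oc(C)nc3-c3ccc(F)cc3)CC2)c1` gives 38.5 nM and compound 1 `Cc1nc(-c2ccccc2)c(C(=O)N2CCN(c3cccc(Cl)c3)CC2)o1` gives 39.2 nM.

The next structure is compound 4 `COc1cc(OC)cc(N2CCN(C(=O)c3oc(C)nc3-c3ccccc3)CC2)c1`, and the change is hydrogen in place of fluoro on an aromatic carbon: 3-fluorophenyl to phenyl, with hydrogen in place of fluoro on an aromatic carbon.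

Among the compounds with values here, one measured step bears directly on this ring: a 1.4-fold lower number from compound 2 to compound 3 (0.14 log units; within the scatter). It swaps 4-fluorophenyl for 3-fluorophenyl and stays within the scatter. Within the data shown here, no measured pair shows fluoro being replaced by hydrogen, so the evidence is indirect. Compound 1 also carries a phenyl here, differs elsewhere, and gives 39.2 nM.

On these numbers, no step beyond the scatter is expected in this assay, and no direction can be favoured. The estimate means a 1.2-fold higher number from compound 3 to compound 4 (0.07 log units; within the scatter), an expected step within the scatter. For compound 4 the expected value is 33 nM, with an estimated range of 16 nM to 68 nM.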

Compound 4, half-maximal inhibitory concentration: 19.2 nM
Compound 4: the middle estimate sits 1.7-fold (0.24 log units) above what was measured; the measured number falls inside the stated range.
By their numbers in this assay, from the lowest: compounds 4, 3, 2 and 1 (each within the scatter of the next, the first and the last beyond it).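

In this assay hydrogen in place of fluoro gives a 1.5-fold lower number from compound 3 to compound 4 (0.17 log units; within the scatter) starting from the 3-fluorophenyl and a 2.0-fold lower number from compound 2 to compound 4 (0.30 log units; within the scatter) starting from the 4-fluorophenyl, so neither fluoro is shown to be needed on this ring. Within the data shown here, with the phenyl held constant, 3,5-dimethoxyphenyl in place of 3-chlorophenyl on the amine nitrogen in a ring gives a 2.0-fold lower number from compound 1 to compound 4 (0.31 log units; beyond the scatter) and is the one step in this set beyond the scatter, though only a modest one. No measured property is available to account for these steps.

The compounds shown leave open how a methoxy, a nitrile or an amine on this phenyl would compare with the unsubstituted ring. They also leave open whether a carboxylic acid at this position would be accepted in this assay.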